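A few compounds are considered here, and "the series" means these few. Any claim that something is new, unique, unknown or untested is made for them only; others in the source may bear on it.

Measured compounds in a functional assay on A-431 cells (Homo sapiens) for cytotoxicity, read by MTT assay, with a stated time of 48 h; a lower number here means a stronger inhibitor, a higher number a weaker inhibitor:
compound 1 `CCCCCCCCCCCCNC(=O)[C@@H](NC(=O)c1cccs1)[C@@H](C)O`, 16600 nM
compound 2 `CCCCCCCCCCCCNC(=O)[C@@H](NC(=O)c1nccc2ccccc12)[C@@H](C)O`, 62800 nM
compound 3 `CCCCCCCCCCCCNC(=O)[C@@H](NC(=O)/C=C/c1ccccc1)[C@@H](C)O`, a limit of the assay, > 200000 nM

Compound 1 holds the lowest of the two numbers shown in this assay. The nearest is compound 2, reached by a 3.8-fold higher number from compound 1 to compound 2 (0.58 log units; beyond the scatter). Compound 3 sits at the limit of the assay, (the limit of > 200000 nM in this assay, at which 1 of the 3 values shown sits), so its gap to compound 1 reads only as an at least 12-fold higher number from compound 1 to compound 3 (1.08 log units; beyond the scatter). The step from compound 2 to compound 3 is an at least 3.1-fold higher number from compound 2 to compound 3 (0.50 log units; beyond the scatter).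

Compound 4 `CCCCCCCCCCCCCCCCCCNC(=O)[C@@H](NC(=O)c1cccs1)[C@@H](C)O` is not yet measured in this assay. It differs from compound 1 by hexyl in place of hydrogen on a saturated chain carbon, ten or more bonds along the chain from an amide-type nitrogen. Within the data shown here, none of the measured steps touches the chain: each of them swaps the group on the carbonyl carbon of the acyl part, while the dodecyl chain stays the same in compounds 1, 2 and 3. Among the measured compounds shown here, there is therefore no measured step that bears on the change from compound 1 to compound 4, and the data give no ground for expecting a step in either direction beyond the scatter.

Compound 4 is accordingly expected to give about 20000 nM in this assay, within 5000 nM to 80000 nM, which would mean an estimated 1.2-fold higher number from compound 1 to compound 4 (0.08 log units; within the scatter).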

Compound 4, half-maximal inhibitory concentration: 33300 nM
Beside the measured number, compound 4's estimate is 1.7-fold (0.22 log units) below it; measured number inside the range.
By their numbers in this assay, from the lowest: compounds 1, 4 and 2 (each within the scatter of the next, the first and the last beyond it). At a limit, above all of these: compound 3.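

This step is the only one shown that touches the chain rather than the group on the carbonyl carbon, and in this assay hexyl in place of hydrogen on a saturated chain carbon, ten or more bonds along the chain from an amide-type nitrogen, gives a 2.0-fold higher number from compound 1 to compound 4 (0.30 log units; within the scatter). The swap on the carbonyl carbon gave a 3.8-fold higher number from compound 1 to compound 2 (0.58 log units; beyond the scatter), whereas this lengthening of the dodecyl chain, with thiophen-2-yl kept in place, gives a step that cannot be told from the scatter, so in this one pair the added hexyl leaves the reading effectively unchanged. Nothing in the evidence at hand bears on this step or offers a reason for it.

The compounds shown leave open whether a shorter chain such as octyl, a still longer chain, or a chain ending in an amine or a carboxylic acid would keep the reading in this range. They also leave open whether the same added hexyl would read the same way with isoquinolin-1-yl or 2-phenylethenyl on the carbonyl carbon.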